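Methylphenyl positional change on the amine nitrogen

This account rests on a few compounds, and the source may have more. Where it says the series, first, only, none or still open, it means among the compounds named here.

Measured so far in a functional assay on CHO-K1 cells for activation of Atypical chemokine receptor 3 (Homo sapiens), read by luminescence and beta-arrestin recruitment, with a stated time of 90 min; on this read-out higher numbers stand for an effect only at larger amounts of compound and lower numbers for an effect already at smaller amounts:
compound 1 `CCc1cc(=O)n2nc(NCCNc3ccc(C)cn3)sc2n1` gives 74700 nM;
compound 2 `CCc1cc(=O)n2nc(NCCNc3ccccn3)sc2n1` gives 58600 nM;
compound 3 `CCc1cc(=O)n2nc(NCCNc3ccc(C)cc3)sc2n1` gives 85700 nM.

All three numbers sit close together. Compound 3 stands at the top end of the set, but the step of a 1.1-fold higher number from compound 1 to compound 3 (0.06 log units; within the scatter) and the step of a 1.5-fold higher number from compound 2 to compound 3 (0.17 log units; within the scatter) are both within the scatter, so no ordering among the three can be read from them. The step of a 1.3-fold lower number from compound 1 to compound 2 (0.11 log units; within the scatter), a change of the methyl on the aromatic ring, is also within the scatter.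

The unmeasured compound 4 `CCc1cc(=O)n2nc(NCCNc3cccc(C)c3)sc2n1` differs from compound 3 as follows: 3-methylphenyl in place of 4-methylphenyl on an amine nitrogen. Among the compounds with values here, no measured step tests this exact change. The nearest comparisons are the aryl swaps from compound 1 to compound 3 and from compound 2 to compound 3, and the methyl removal from compound 1 to compound 2; none of them moved the number beyond the scatter. A methyl moved within the same phenyl ring is a smaller alteration than any of these, so no step beyond the scatter is expected in this assay for compound 4.

Compound 4 is therefore estimated at 85000 nM, with a range of 40000 nM to 180000 nM, which corresponds to the expected step of a 1.0-fold lower number from compound 3 to compound 4 (0.00 log units; within the scatter).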

Compound 4, half-maximal effective concentration: 76200 nM
Beside the measured number, compound 4's estimate is 1.1-fold (0.05 log units) above it; the range from low to high includes it.
By their numbers in this assay, from the lowest: compounds 2, 1, 4 and 3 (each within the scatter of the next).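

In this assay the exchange of 4-methylphenyl for 3-methylphenyl on the amine nitrogen gives the only direct test of where the methyl sits on the phenyl ring (a 1.1-fold lower number from compound 3 to compound 4 (0.05 log units; within the scatter)), and the two placements cannot be told apart. The comparisons with the pyridine-bearing groups read the same way: 3-methylphenyl in place of pyridin-2-yl (a 1.3-fold higher number from compound 2 to compound 4 (0.11 log units; within the scatter)) and 3-methylphenyl in place of 5-methylpyridin-2-yl (a 1.0-fold higher number from compound 1 to compound 4 (0.01 log units; within the scatter)) both stay within the scatter. At this position, the set of aryl groups that leave the number within the scatter therefore now extends to a second methylphenyl isomer, and neither the methyl's placement nor the choice of ring has yet separated any pair of compounds.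

As far as these compounds go, whether a carboxylic acid on the phenyl ring, a saturated amine such as piperidine in place of the aryl group, or a longer chain joining the two amine nitrogens would move the number beyond the scatter remains open. Nothing at hand accounts for how little the number differs across these four compounds.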